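This account rests on a few compounds, and the source may have more. Where it says the series, first, only, none or still open, it means among the compounds named here.

Of the compounds shown here, three built on a shared core have been tested in an ADME assay on BHK cells (Mesocricetus auratus) for cytotoxicity, read by MTT assay, with a stated time of 96 h; a higher number here means that more compound is tolerated, a lower number that less compound is tolerated. Compound 1 `CN1CCN(CC(=O)Nc2ccc(-c3nc4cc(Cl)c(Cl)cc4[nH]3)cc2)CC1` gives 41000 nM in this assay. Compound 2 `O=[N+]([O-])c1ccc(-c2nc3cc(C(F)(F)F)ccc3[nH]2)cc1` gives 18000 nM, so compound 1 has the higher of the two numbers, a gap that lies beyond the usual scatter. Compound 3 `COc1ccc(-c2nc3cc(C(C)=O)ccc3[nH]2)c(OC)c1` reaches only a limit of this assay, > 100000 nM, with no exact number behind it; that is the case described by the limit of > 100000 nM in this assay, at which 1 of the 3 values shown sits.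

Compound 4 `CC(=O)Nc1ccc(-c2nc3cc(Cl)c(Cl)cc3[nH]2)cc1` has not yet been measured in this assay. It differs from compound 1 in one place: hydrogen in place of 4-methylpiperazin-1-yl on a saturated chain carbon bound to a carbonyl carbon. For the measured compounds named here, no pair of measured compounds differs by a change of this kind, so there is no measured step to lean on. The step from compound 1 to compound 4 is expected to be small, a 1.2-fold higher number from compound 1 to compound 4 (0.09 log units; within the scatter), with no clear direction beyond the scatter. Compound 4 is therefore estimated to give 50000 nM in this assay, somewhere between 15000 nM and 150000 nM.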

Compound 4, half-maximal cytotoxic concentration: > 100000 nM
Compound 4: only a limit was reported (the forecaster's own chance of this, stated with the estimate: 30%); at least 2.0-fold (0.30 log units) between middle value and limit.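

For the compounds shown here, until now, no measured pair showed what a change at this place does: a saturated chain carbon bound to a carbonyl carbon. Replacing 4-methylpiperazin-1-yl with hydrogen, which turns the (4-methylpiperazin-1-yl)methyl group into methyl, gives an at least 2.4-fold higher number from compound 1 to compound 4 (0.38 log units; beyond the scatter) in this assay, so in this pair the loss of the ring goes with more compound being tolerated. Compound 4 gives > 100000 nM, which is a limit and not an exact number: the limit of > 100000 nM in this assay, at which 2 of the 4 values shown sit.

On these data alone, this single pair is all that speaks for the position, and the full size of the step stays unknown. The compounds shown leave open whether a smaller amine such as dimethylamino, a morpholine ring or a carboxylic acid at this place would behave like 4-methylpiperazin-1-yl or like hydrogen.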